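A few compounds are considered here, and "the series" means these few. Any claim that something is new, unique, unknown or untested is made for them only; others in the source may bear on it.

- Compound 1 `COc1ccc(COc2cc(O)c3c(=O)cc(C)oc3c2[C@H]2CCN(C)C[C@H]2O)cc1`: 15%
- Compound 2 `Cc1cc(=O)c2c(O)cc(OCc3ccccc3Br)c([C@H]3CCN(C)C[C@H]3O)c2o1`: 30%

Going by the values given here, in a functional assay on MIA PaCa-2 cells (Homo sapiens) for inhibition, read by MTT assay, with a stated time of 48 h, tested at 10 uM (a higher number here means more inhibition of growth at the concentration tested, a lower number less inhibition of growth), compound 1 gives 15%, the lower of the only two numbers available so far. Compound 2 gives 30% in the same test. Both values describe partial inhibition of growth, and the next question concerns compound 3 `Cc1cc(=O)c2c(O)cc(OC/C=C/c3ccccc3)c([C@H]3CCN(C)C[C@H]3O)c2o1`, which has not yet been measured.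

The change from compound 1 is 2-phenylethenyl in place of 4-methoxyphenyl on a saturated chain carbon bound to an oxygen on an aromatic ring. In words, 2-phenylethenyl stands in place of 4-methoxyphenyl on a saturated chain carbon bound to an oxygen on an aromatic ring. The rest of the molecule stays the same.

Among the compounds with values here, one measured step bears on this change, since it also removes 4-methoxyphenyl from that place, with 2-bromophenyl entering instead. That step is a number 15 percentage points higher from compound 1 to compound 2 (beyond the scatter), a modest size. A single step involving a different group is thin evidence, so only a smaller rise in this assay is expected, and no change at all remains possible.

The expected step is a number 9 percentage points higher from compound 1 to compound 3 (within the scatter). For compound 3 the estimated value is 24%, with an expected range from 8% to 45%.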

Compound 3, percent growth inhibition at one concentration: 11%
For compound 3 the middle estimate is 13 percentage points above the measured one, within the range that was stated.
By their numbers in this assay, from the lowest: compounds 3 and 1 (each within the scatter of the next); then compound 2.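

In this assay the step of a number 4 percentage points lower from compound 1 to compound 3 (within the scatter) shows that, at this place on a saturated chain carbon bound to an oxygen on an aromatic ring, 2-phenylethenyl cannot be told apart from 4-methoxyphenyl, although the methoxy oxygen leaves and a double bond outside the aromatic ring enters. The other comparison, a number 19 percentage points lower from compound 2 to compound 3 (beyond the scatter), separates 2-phenylethenyl from 2-bromophenyl, so the earlier rise from 4-methoxyphenyl to 2-bromophenyl does not come with every replacement of 4-methoxyphenyl and, among these three compounds, is seen only with compound 2. Nothing available here explains why 2-bromophenyl stands apart from the other two groups.

The three groups shown all carry a six-membered aromatic ring of carbon only, so it remains open how this place responds to a group without such a ring, such as a plain longer alkyl chain, an amine or a carboxylic acid. On these data alone, it also remains open whether the bromine itself matters, which a comparison of compound 2 with the matching 2-chlorophenyl or unsubstituted phenyl group could begin to test.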